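A few compounds are considered here, and "the series" means these few. Any claim that something is new, unique, unknown or untested is made for them only; others in the source may bear on it.

Measured compounds:
compound 1 `CC(C)(C)c1ccc(CCC(=S)NCc2ccc(NS(C)(=O)=O)c(F)c2)cc1` — 40 nM
compound 2 `CC(C)(C)c1ccc(CCC(=S)NCc2ccc(NS(C)(=O)=O)c(I)c2)cc1` — 300 nM

Both numbers come from a functional assay for antagonist activity at transient receptor potential cation channel subfamily V member 1 (Rattus norvegicus); on this read-out lower numbers stand for stronger inhibition and higher numbers for weaker inhibition. Among the measured compounds shown here, compound 1 stands at the lowest of the two numbers; its nearest neighbour is compound 2, reached by a 7.5-fold higher number from compound 1 to compound 2 (0.88 log units; beyond the scatter), the only single-place step in the set, in which the ring bearing the methanesulfonamido group is altered.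

Compound 3 `C=Cc1cc(CNC(=S)CCc2ccc(C(C)(C)C)cc2)cc(F)c1NS(C)(=O)=O` has not yet been measured. It differs from compound 1 by vinyl in place of hydrogen on an aromatic carbon. For the measured compounds named here, no measured pair touches the position in question, so the step from compound 1 to compound 2 bears on it only loosely, as the sole indication of how this ring responds to a change: there, one substitution on an aromatic carbon gave a move beyond the scatter, toward weaker inhibition. With nothing closer to lean on, a small added group here is expected to cost at most a modest amount; the step from compound 1 to compound 3 is estimated at a 2.0-fold higher number from compound 1 to compound 3 (0.30 log units; within the scatter) in this assay, with a result within the scatter also plausible. Compound 3 is therefore expected at 80 nM, in the range 25 nM to 300 nM.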

Compound 3, half-maximal inhibitory concentration: 32 nM
Estimate against measurement, compound 3: 2.5-fold (0.40 log units) above; measured number inside the range.
By their numbers in this assay, from the lowest: compounds 3 and 1 (each within the scatter of the next); then compound 2.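

In this assay, placing vinyl on the aromatic carbon ortho to a methanesulfonamido group and meta to a fluoro group leaves the number indistinguishable from that of the parent, with a 1.3-fold lower number from compound 1 to compound 3 (0.10 log units; within the scatter). Among the compounds shown here, this is the first reading at this position, and it shows that a group of 2 heavy atoms with one double bond can stand here without a shift beyond the scatter, whereas exchanging the fluoro group for iodo gave a 7.5-fold higher number from compound 1 to compound 2 (0.88 log units; beyond the scatter); within these compounds, the ring's response therefore depends on the place and the group changed. Nothing at hand accounts for this result.

The compounds shown leave open whether the double bond of the vinyl group matters, which ethyl on the same carbon would test, and whether an amine, a carboxylic acid or a longer chain such as allyl would also stay within the scatter of compound 1. They also leave open whether vinyl at this position would read the same with iodo in place of the fluoro group.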